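A few compounds are considered here, and "the series" means these few. Any claim that something is new, unique, unknown or untested is made for them only; others in the source may bear on it.

Working notes on the series. Compound 1 `CNc1c(C#N)c2c(N)ncnc2n1COCCOC` carries a methylamino group and a cyano group on the shared core. In a functional assay on KB cells (Homo sapiens) for inhibition (a higher number here means a weaker inhibitor, a lower number a stronger inhibitor), compound 1 gives only a limit of the assay, > 100000 nM. Compound 2 `COCCOCn1c(N)c(C(N)=O)c2c(N)ncnc21` gives in this assay likewise only a limit, > 100000 nM. Compound 3 `Cc1ccc(Cn2c(N)c(C#N)c3c(N)ncnc32)cc1` gives in this assay also only a limit, > 100000 nM. Among the measured compounds shown here, compound 1 thus sits with the other two at the limit of > 100000 nM in this assay, at which 3 of the 3 values shown sit, so no step between measured compounds can be sized and no direction can be read from the measured set.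

Compound 4 `COCCOCn1c(Br)c(C#N)c2c(N)ncnc21` differs from compound 1 by bromo in place of methylamino on an aromatic carbon. For the measured compounds named here, no measured pair shows this change, so its effect cannot be taken from the numbers. With every measured value at the limit of > 100000 nM in this assay, at which 3 of the 3 values shown sit, the expected step is a number no higher from compound 1 to compound 4 (the limit leaves the size open), that is none beyond the scatter, with compound 4 most likely returning a limit again. Compound 4 is expected to give in this assay about 100000 nM, estimated between 30000 nM and 300000 nM.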

Compound 4, half-maximal inhibitory concentration: > 100000 nM
Compound 4 gave a limit, no number; the forecaster's own chance of this, stated with the estimate: 75%; the middle value sits exactly at the limit.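

Compound 1 and compound 4 both return only a limit, so no step can be read for bromo in place of methylamino: the limit of > 100000 nM in this assay, at which 4 of the 4 values shown sit.

The compounds shown leave open whether any change on the shared core yields a measurable value in this assay.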